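The source may report more compounds than this note shows. Statements on the series, on what has been measured and on what is new or still open speak of the compounds shown alone.

Compound 1 `CC(C)C(/C=C1\NC(=O)NC1=O)c1ccc(-c2ccc3cccc(F)c3c2)[nH]c1=O` and compound 2 `CC(C)[C@@H](c1ccc(-c2ccc3cccc(F)c3c2)[nH]c1=O)[C@@H]1OC(=O)NC1=O` were tested in an assay on membranes from Chem-1 cells for displacement of a labelled ligand from prostaglandin E2 receptor EP3 subtype (Homo sapiens), read by scintillation counting, with a stated time of 2 h; on this read-out higher numbers stand for weaker inhibition and lower numbers for stronger inhibition. Compound 1 gives 43 nM, the lower of the two numbers seen so far, while compound 2 gives 85 nM, a gap that stays within the usual scatter of such measurements. Compound 3 `CC(C)C(c1ccc(-c2ccc3cccc(F)c3c2)[nH]c1=O)C1C(=O)NC(=O)N1C` has not yet been measured. It differs from compound 1 by a group of 8 heavy atoms (4 carbon, 2 nitrogen, 2 oxygen; one five-membered non-aromatic ring with 2 hetero atoms) in place of a group of 8 heavy atoms (4 carbon, 2 nitrogen, 2 oxygen; one five-membered non-aromatic ring with 2 hetero atoms), on a saturated chain carbon bound to an aromatic carbon and a saturated chain carbon. Going by the values given here, with no comparable step measured between the compounds already in hand, only a modest expectation can be formed; compound 3 is estimated to land at 120 nM, somewhere between 40 nM and 400 nM, with an expected step from compound 1 to compound 3 of a 2.8-fold higher number from compound 1 to compound 3 (0.45 log units; beyond the scatter).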

Compound 3, inhibition constant: 46 nM
Estimate against measurement, compound 3: 2.6-fold (0.42 log units) above; low and high end bracket the measured number.
By their numbers in this assay, from the lowest: compounds 1, 3 and 2 (each within the scatter of the next).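

In this assay, placing 3-methyl-2,5-dioxoimidazolidin-4-yl on this saturated chain carbon, in place of the ring group of compound 1, gives a 1.1-fold higher number from compound 1 to compound 3 (0.03 log units; within the scatter), so the two compounds cannot be told apart. The entering group has 1 hydrogen-bond donor and 2 double bonds outside aromatic rings, against 2 and 3 in the leaving group, and the step still stays within the scatter. Nothing available explains this result. On these data alone, whether a carboxylic acid or an amine on this carbon would give a similar number remains open.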